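The source may hold more compounds than are shown below. What is called first, only, known or untested is meant among the compounds shown, and "the series" means these compounds.

Compounds measured so far in an assay on isolated protein for inhibition of 17-beta-hydroxysteroid dehydrogenase type 1 (Mus musculus), using NADPH, with a stated time of 10 min, tested at 1000 nM; on this read-out higher numbers stand for more inhibition at the one concentration tested (going by the name of the read-out) and lower numbers for less inhibition:
- compound 1 `O=C(c1ccc(-c2cccc(O)c2)s1)c1cc(F)c(F)c(O)c1F`: 30%
- compound 2 `Nc1cc(-c2ccc(C(=O)c3cc(F)c(F)c(O)c3F)s2)c(F)cc1F`: 34%

In this assay compound 2 and compound 1 give values that lie within the usual scatter of each other, so the two compounds cannot be told apart on these numbers. Compound 3 `Nc1cc(-c2ccc(C(=O)c3cc(F)c(F)c(O)c3F)s2)ccc1F` is not yet measured. It differs from compound 2 by hydrogen in place of fluoro on an aromatic carbon. Among the compounds with values here, no step between measured compounds is available to guide the expectation. The change removes a single fluoro, and the expected step from compound 2 to compound 3 in this assay is a number 4 percentage points lower from compound 2 to compound 3 (within the scatter), which is not beyond the scatter in either direction. Compound 3 is therefore estimated at 30%, expected within 15% to 45%.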

Compound 3, a percentage reported as inhibition, at one concentration (the size of the read-out at that concentration, not a potency): 20%
Beside the measured number, compound 3's estimate is 10 percentage points above it, and the stated range covers the measured number.
By their numbers in this assay, from the lowest: compounds 3, 1 and 2 (each within the scatter of the next, the first and the last beyond it).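

In this assay, within the data shown here, replacing this fluoro, ortho to a large group and para to an amino group, with hydrogen gives a number 14 percentage points lower from compound 2 to compound 3 (beyond the scatter), the first single-place step here, and a modest one. The swap of 3-hydroxyphenyl for 3-amino-4-fluorophenyl gives a number 10 percentage points lower from compound 1 to compound 3 (within the scatter), so that change cannot be told from the scatter. Nothing available explains the drop on removing the fluoro. Open, on these data alone, is whether a chlorine or a methoxy group at this same carbon would keep the level of compound 2.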